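Amide-side change in an alkynylpyridine carboxamide series

The source may report more compounds than this note shows. Statements on the series, on what has been measured and on what is new or still open speak of the compounds shown alone.

Measured so far in an ADME assay on HEK293 cells for agonist activity at metabotropic glutamate receptor 5 (Rattus norvegicus), read by fluorescence and calcium flux; a higher number here means a larger maximal response, a lower number a smaller maximal response:
compound 1 `C[C@@H](NC(=O)c1ccc(C#Cc2ccccc2)cn1)C(C)(C)O` gives 43.2%
compound 2 `Cc1ccccc1C#Cc1ccc(C(=O)N[C@H](C)C(C)(C)O)nc1` gives 24.1%
compound 3 `C[C@H](NC(=O)c1ccc(C#Cc2cccc(F)c2)cn1)C(C)(C)C` gives 20%

Compound 3 holds the lowest of the three numbers. Its gap to compound 2 lies within the scatter, so no order between the two can be read; its gap to compound 1 lies beyond the scatter. For the measured compounds named here, the only step between compounds that differ in one place is a number 19.1 percentage points lower from compound 1 to compound 2 (beyond the scatter), and that change sits on an aromatic carbon, not on the amide nitrogen.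

Compound 4 `O=C(NCC1CCC1)c1ccc(C#Cc2cccc(F)c2)cn1` is not yet measured. It differs from compound 3 by cyclobutylmethyl in place of 1,2,2-trimethylpropyl on an amide-type nitrogen. Going by the values given here, no measured pair changes this part of the molecule, so nothing in the data shows how this assay responds to a change on the amide-type nitrogen. The step of a number 2 percentage points higher from compound 3 to compound 4 (within the scatter) is therefore expected to stay within the scatter. For compound 4 in this assay, the estimated value is 22%, between 8% and 40%.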

Compound 4, largest response reached (reported as efficacy), in percent of the reference or control that the assay uses: 4.7%
Estimate against measurement, compound 4: 17.3 percentage points above, and the stated range ends above it.
By their numbers in this assay, from the lowest: compound 4; then compounds 3 and 2 (each within the scatter of the next); then compound 1.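

The amide-type nitrogen now has its first readable step in this assay: cyclobutylmethyl in place of 1,2,2-trimethylpropyl gives a number 15.3 percentage points lower from compound 3 to compound 4 (beyond the scatter) on the same fluorinated core. The maximal response therefore depends on this substituent, and not only on the aromatic carbon changed between the earlier pair. For the compounds shown here, the single step combines the entry of a four-membered ring, the loss of the defined stereocentre and one heavy atom fewer, and no measured evidence explains the drop.

Which of these features matters remains unresolved by this pair. A straight pentyl chain or a cyclopentylmethyl group on the same nitrogen would help separate the ring from the branching, and the open question is whether either would read closer to compound 3 or to compound 4.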